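This account rests on a few compounds, and the source may have more. Where it says the series, first, only, none or still open, it means among the compounds named here.

Measured compounds:
- compound 1 `CN1CCN(c2ccc(/C=C3/SC(Nc4ccccc4)=NC3=O)cc2)CC1`: 2500 nM
- compound 2 `CCN(CC)c1ccc(/C=C2/SC(N(c3ccccc3)c3ccccc3)=NC2=O)cc1`: > 100000 nM

Two measured compounds frame this account. In a functional assay on H460/TaxR cells (Homo sapiens) for cytotoxicity, read by sulforhodamine B assay, with a stated time of 48 h (on this read-out higher numbers stand for an effect only at larger amounts of compound and lower numbers for an effect already at smaller amounts), compound 1 gives 2500 nM. For compound 2 the result in this assay is only a limit of the assay, > 100000 nM, and not a number. Compound 2 thus stands at the upper boundary of what this assay can report, a point noted as the limit of > 100000 nM in this assay, at which 1 of the 2 values shown sits. Among the measured compounds shown here, compound 1 and compound 2 differ in two places at once, so their values show only that one compound gives a number and the other does not.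

Compound 3 `CN1CCN(c2ccc(/C=C3/SC(N(c4ccccc4)c4ccccc4)=NC3=O)cc2)CC1` has not yet been measured. It differs from compound 2 in one place: 4-methylpiperazin-1-yl in place of diethylamino on an aromatic carbon. For the measured compounds named here, no measured pair isolates this change. Compound 3 keeps the part of compound 2 that compound 1 lacks, so the expected step from compound 2 to compound 3, an at least 2.0-fold lower number from compound 2 to compound 3 (0.30 log units; that floor lies within the scatter), is a downward one of uncertain size. Compound 3 is therefore estimated at 50000 nM, within a range from 5000 nM to 200000 nM.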

Compound 3, half-maximal effective concentration: > 100000 nM
Compound 3 gave a limit, no number; the forecaster's own chance of this, stated with the estimate: 55%; middle value at least 2.0-fold (0.30 log units) from the limit.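

In this assay, compound 1 and compound 3 now isolate a single change, phenyl in place of hydrogen on a nitrogen on an aromatic ring, and that change gives an at least 40-fold higher number from compound 1 to compound 3 (1.60 log units; beyond the scatter) on the shared core. Among the compounds shown here, this is the first readable step, and it shows that this one position alone separates a compound that gives a number from one that gives only a limit, with 4-methylpiperazin-1-yl held constant. The step that exchanges diethylamino for 4-methylpiperazin-1-yl cannot be read, since compound 2 and compound 3 both give only a limit, and the second phenyl on that nitrogen is the feature they share at the top of the range: the limit of > 100000 nM in this assay, at which 2 of the 3 values shown sit.

Going by these compounds, it remains open whether a methyl group or an acetyl group on that nitrogen would give a number, or whether the hydrogen is needed for one. On these data alone, it also remains open how diethylamino and 4-methylpiperazin-1-yl compare when the nitrogen keeps its hydrogen, the one setting in which that exchange could be read as a number.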